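Swapping the group on the ring nitrogen once more

The compounds below may be only part of what the source reports. "The series", "measured", "known", "first", "only" and "open" are said of these compounds alone.

Of the compounds shown here, two sharing one core have been measured in an assay on U2OS cells for inhibition of secreted frizzled-related protein 1 (Homo sapiens), read by a luciferase reporter, with a stated time of 18 h; a lower number here means that less compound is needed, a higher number that more compound is needed for the effect. Compound 1 `O=C(c1cccnc1)N1CCC(NS(=O)(=O)c2cc(S(=O)(=O)c3ccccc3)ccc2C(F)(F)F)CC1` gives 120 nM. Going by the values given here, compound 2 `O=C(O)c1ccc(N2CCC(NS(=O)(=O)c3cc(S(=O)(=O)c4ccccc4)ccc3C(F)(F)F)CC2)cc1` gives 230 nM, the highest of the two numbers, though its only neighbour, compound 1, sits within the scatter, as the step of a 1.9-fold higher number from compound 1 to compound 2 (0.28 log units; within the scatter) shows. That step exchanged one group on the amine nitrogen in a ring for another and moved the number by no more than repeated measurements would.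

Compound 3 `O=C(CC1CCNCC1)N1CCC(NS(=O)(=O)c2cc(S(=O)(=O)c3ccccc3)ccc2C(F)(F)F)CC1` has not yet been measured. It differs from compound 2 in the same spot: ((piperidin-4-yl)methyl)carbonyl in place of 4-carboxyphenyl on an amine nitrogen in a ring. Among the compounds with values here, only the step from compound 1 to compound 2 bears on this, and it was within the scatter, so a group change at this nitrogen has so far left the number about where it was, and compound 3 brings back a carbonyl on that nitrogen, as in compound 1. No step beyond the scatter is therefore expected in this assay , and the estimated step is a 1.5-fold lower number from compound 2 to compound 3 (0.19 log units; within the scatter). Compound 3 is expected to give about 150 nM, with a range from 50 nM to 500 nM.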

Compound 3, half-maximal effective concentration: 210 nM
The estimate for compound 3 lay 1.4-fold (0.15 log units) below the measured number, and the stated range covers the measured number.
By their numbers in this assay, from the lowest: compounds 1, 3 and 2 (each within the scatter of the next).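

In this assay, the exchange of 4-carboxyphenyl for ((piperidin-4-yl)methyl)carbonyl on the amine nitrogen in a ring gives a 1.1-fold lower number from compound 2 to compound 3 (0.04 log units; within the scatter), so an aromatic ring of carbon only and a non-aromatic ring with a nitrogen, each with 9 heavy atoms in its group, give numbers that cannot be told apart at this position. With the carbonyl kept on that nitrogen, (piperidin-4-yl)methyl in place of pyridin-3-yl on the carbonyl carbon gives a 1.8-fold higher number from compound 1 to compound 3 (0.24 log units; within the scatter), which extends the same picture to a change made one step further out from the ring nitrogen. Nothing measured here explains why the number stays put across these three groups.

From the compounds shown here alone, all three compounds carry a sizeable ring-bearing group at this nitrogen, so it remains open whether a bare hydrogen or a single methyl there would shift the number beyond the scatter. Going by these compounds, it is equally open whether a long unbranched alkyl chain, or a simple amine at the end of such a chain, would leave the number where these three compounds place it.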